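The compounds below may be only part of what the source reports. "The series", "measured", "known", "first", "only" and "open" are said of these compounds alone.

Measured compounds:
compound 1, `CCN(CC)CCNC(=O)c1ccc(C(CC)(CC)c2ccc(OCC(O)C(C)(C)C)c(C)c2)n1CC`: 110 nM
compound 2, `CCN(CC)CCCNC(=O)c1ccc(C(CC)(CC)c2ccc(OCC(O)C(C)(C)C)c(C)c2)n1CC`: 66 nM
compound 3, `CCn1c(C(=O)N(C)CCC#N)ccc1C(CC)(CC)c1ccc(OCC(O)C(C)(C)C)c(C)c1`: 1960 nM

These three compounds share one core and differ only in the amide portion. In an assay on HL-60 cells for agonist activity at vitamin D3 receptor (Homo sapiens), read by microscopy, with a stated time of 96 h (a higher number here means that more compound is needed for the effect, a lower number that less compound is needed), compound 1 gives 110 nM and compound 2 gives 66 nM, a pair that differs by a 1.7-fold lower number from compound 1 to compound 2 (0.22 log units; within the scatter). Compound 3 gives 1960 nM in this assay, the highest number of the three: it stands an 18-fold higher number from compound 1 to compound 3 (1.25 log units; beyond the scatter) and a 30-fold higher number from compound 2 to compound 3 (1.47 log units; beyond the scatter).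

Compound 4, `CCn1c(C(=O)N(CCC#N)CCC#N)ccc1C(CC)(CC)c1ccc(OCC(O)C(C)(C)C)c(C)c1`, has not yet been measured. It differs from compound 3 in one place: cyanomethyl in place of hydrogen on a saturated chain carbon bound to an amide-type nitrogen. For the measured compounds named here, compound 3 is the only measured compound with a nitrile, so no measured step repeats this exact change. The steps that bear on it are those into compound 3, which show that exchanging the diethylaminoalkyl amide for the cyanoethyl-methyl amide raised the number greatly; compound 4 carries a second cyanoethyl chain and no basic amine, so nothing in the shown steps argues for a return toward compound 1 or compound 2. In this assay compound 4 is therefore expected to give a number close to that of compound 3, most likely somewhat higher, with an estimated step of a 1.4-fold higher number from compound 3 to compound 4 (0.15 log units; within the scatter). The estimate for compound 4 in this assay is 2800 nM, with a range from 900 nM to 9000 nM.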

Compound 4, half-maximal effective concentration: 97 nM
For compound 4 the middle estimate is 29-fold (1.46 log units) above the measured one, and the stated range ends above it.
By their numbers in this assay, from the lowest: compounds 2, 4 and 1 (each within the scatter of the next); then compound 3.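

In this assay, for the compounds shown here, cyanomethyl in place of hydrogen on a saturated chain carbon bound to an amide-type nitrogen gives a 20-fold lower number from compound 3 to compound 4 (1.31 log units; beyond the scatter), so the change from methyl to 2-cyanoethyl at this place on the amide matters a great deal, which the earlier compounds could not show. The new amide also stands level with the amides that carry a diethylamino group, at a 1.5-fold higher number from compound 2 to compound 4 (0.17 log units; within the scatter) and a 1.1-fold lower number from compound 1 to compound 4 (0.05 log units; within the scatter), so the high number of compound 3 does not follow from the nitrile or from the absence of diethylamino alone. Nothing in the data shown accounts for this large step.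

As far as these compounds go, it remains open whether a plain propyl chain in place of the second 2-cyanoethyl would keep the number near that of compound 4 or near that of compound 3, a comparison that would separate the nitrile from the chain itself. Also open, from the compounds shown here alone, is how a longer chain such as 3-cyanopropyl, or a carboxylic acid or an amine at the end of that chain, would read in this assay.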